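A few compounds are considered here, and "the series" means these few. Any claim that something is new, unique, unknown or untested is made for them only; others in the source may bear on it.

Compound 1 `C[C@H](c1ccc(N2CC[C@H](NS(=O)(=O)c3ccc4cc(Cl)ccc4c3)C2=O)c(F)c1)N(C)C`: 43%
Compound 2 `CN[C@H](C)c1ccc(N2CC[C@H](NS(=O)(=O)c3ccc4cc(Cl)ccc4c3)C2=O)c(F)c1`: > 10% (a limit)

In an in vivo ADME assay on the whole organism (strain Sprague-Dawley) for pharmacokinetics, with Rattus norvegicus as the target (on this read-out lower numbers stand for lower oral bioavailability and higher numbers for higher oral bioavailability), compound 2 has no exact number, only the limit > 10%. Among the measured compounds shown here, the one measured step, a step that the limit leaves unreadable from compound 1 to compound 2, puts hydrogen in place of methyl on an amine nitrogen and gives no size to carry over. Compound 3 `CN[C@@H](C)c1ccc(N2CC[C@H](NS(=O)(=O)c3ccc4cc(Cl)ccc4c3)C2=O)c(F)c1` differs from compound 2 in this way: the two compounds have the same atoms and bonds and differ only in configuration as drawn: 1 of 2 stereo elements differ; a stereocentre at a saturated chain carbon is drawn R in compound 2 and S in compound 3. For the measured compounds named here, no measured step changes a stereocentre, so no direction is expected. Going by the values given here, the only exact value, 43% for compound 1, gives a loose guide to the level. The expected change is a step that the limit leaves unreadable from compound 2 to compound 3. Compound 3 is estimated at 30%, with a range from 10% to 55%.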

Compound 3, oral bioavailability: > 15%
Compound 3: a limit, no number (the forecaster's own chance of this, stated with the estimate: 20%); the middle value does not contradict the limit.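

Compound 3 has only a limit for oral bioavailability, > 15%. Among the compounds shown here, no new step from compound 1 or compound 2 to compound 3 can be read. On these data alone, whether the stereocentre drawn R in compound 2 and S in compound 3 changes oral bioavailability stays open.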